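The source may report more compounds than this note shows. Statements on the series, on what has been measured and on what is new or still open speak of the compounds shown alone.

Compound 1 `O=C1CN(C2CCCC2)c2nc(Nc3ccc(N4CCCCC4)cc3)ncc2N1`: 5540 nM in a functional assay on HT-29 cells (Homo sapiens) for inhibition, read by MTT assay, with a stated time of 48 h; a lower number here means a stronger inhibitor, a higher number a weaker inhibitor
Compound 2 `CC1CCN(c2ccc(Nc3ncc4c(n3)N(C3CCCC3)CC(=O)N4)cc2)CC1`: 5040 nM in this assay
Compound 3 `O=C1CN(C2CCCC2)c2nc(Nc3ccc(N4CCCCC4)cn3)ncc2N1`: 21100 nM in this assay

The change from compound 1 to compound 2, (methyl in place of hydrogen on a saturated ring carbon), gave a 1.1-fold lower number from compound 1 to compound 2 (0.04 log units; within the scatter). Compound 3 carries a different core; the difference between the two cores is not broken down here, and compound 3 gives the highest number of the three in this assay. Compound 4 `CC1CCN(c2ccc(Nc3ncc4c(n3)N(C3CCCC3)CC(=O)N4)nc2)CC1` arises from compound 3 by the same change, (methyl in place of hydrogen on a saturated ring carbon), on the same place. On the strength of compound 1 and compound 2, where a 1.1-fold lower number from compound 1 to compound 2 (0.04 log units; within the scatter) was seen, the step for compound 4 is expected to be a 1.1-fold lower number from compound 3 to compound 4 (0.05 log units; within the scatter). Compound 4 is therefore estimated at 19000 nM, with a range from 8000 nM to 45000 nM.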

Compound 4, half-maximal inhibitory concentration: > 30000 nM
Compound 4: a limit, no number (the forecaster's own chance of this, stated with the estimate: 10%); middle value at least 1.5-fold (0.19 log units) away from the limit.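

In this assay compound 4 gives > 30000 nM and that value is a limit of the assay, not a number. Going from piperidin-1-yl to 4-methylpiperidin-1-yl on this core gives an at least 1.4-fold higher number from compound 3 to compound 4 (0.15 log units; that floor lies within the scatter) and so the step has a floor but no measured size. This does not show that the change behaves the same or differently on the two cores, so carrying it from one core to the other remains unsettled: the same change on two cores in this assay, a 1.1-fold lower number (0.04 log units; within the scatter) from compound 1 to compound 2 and an at least 1.4-fold higher number (0.15 log units; that floor lies within the scatter) from compound 3 to compound 4; the limit leaves it open whether they differ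

The compounds shown leave open the actual number for compound 4. They also leave open what an ethyl group or a hydroxyl group in place of the methyl would give on either core.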